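The source may hold more compounds than are shown below. What is called first, only, known or untested is meant among the compounds shown, and "the series" means these compounds.

Of the compounds shown here, three sharing one core have been measured in a functional assay on HT-29 cells (Homo sapiens) for inhibition, read by MTT assay, with a stated time of 48 h; a higher number here means a weaker inhibitor, a lower number a stronger inhibitor. Compound 1 `COc1cc(-c2cc(-c3ccc(Br)cc3)nc(-c3ccccc3)n2)cc(OC)c1OC` gives 3170 nM. Compound 2 `COc1cc(-c2cc(-c3cccc([N+](=O)[O-])c3)nc(-c3ccccc3)n2)cc(OC)c1OC` reads > 25000 nM, which is a limit and not a number. Compound 3 `COc1cc(-c2cc(-c3ccc(C)cc3)nc(-c3ccccc3)n2)cc(OC)c1OC` reads > 25000 nM, which is also a limit and not a number. Compound 3 therefore stands at the limit of > 25000 nM in this assay, at which 2 of the 3 values shown sit.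

Compound 4 `COc1ccc(-c2cc(-c3cc(OC)c(OC)c(OC)c3)nc(-c3ccccc3)n2)c(OC)c1` carries 2,4-dimethoxyphenyl in place of the 4-methylphenyl of compound 3: 2,4-dimethoxyphenyl in place of 4-methylphenyl on an aromatic carbon. Two measured changes at this same place bear on it. They are an at least 7.8-fold higher number from compound 1 to compound 2 (0.89 log units; beyond the scatter) and an at least 7.8-fold higher number from compound 1 to compound 3 (0.89 log units; beyond the scatter), while the remaining comparison is a step that the two limits leave unreadable from compound 2 to compound 3. Neither of the two readable steps involves a methoxy group, so they show that this place matters but not how compound 4 will behave. Of these compounds, only compound 1, at 3170 nM, gives a number, so a modest step towards a lower number in this assay is expected, if any can be read at all. The expected step is an at least 1.2-fold lower number from compound 3 to compound 4 (0.09 log units; that floor lies within the scatter). The estimate for compound 4 is 20000 nM, with an expected range from 6000 nM to 50000 nM.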

Compound 4, half-maximal inhibitory concentration: > 25000 nM
Compound 4 gave a limit, no number; the forecaster's own chance of this, stated with the estimate: 55%; at least 1.2-fold (0.09 log units) between middle value and limit.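

In this assay, the 2,4-dimethoxyphenyl group of compound 4 also ends at the limit of the assay, which is a limit and not a number, so compound 1 remains the only compound shown with a measured number: the limit of > 25000 nM in this assay, at which 3 of the 4 values shown sit.

The exchange of 4-bromophenyl for 2,4-dimethoxyphenyl gives an at least 7.8-fold higher number from compound 1 to compound 4 (0.89 log units; beyond the scatter), which extends the loss seen with 3-nitrophenyl and 4-methylphenyl to a group carrying methoxy substituents at this place. The steps among compounds 2, 3 and 4 cannot be read, so no order among these three groups can be given.

As far as these compounds go, how far compounds 2, 3 and 4 lie beyond the limit remains open. From the compounds shown here alone, it also remains open whether the number of compound 1 is particular to bromo, or whether 4-chlorophenyl or 4-aminophenyl at this place would also give a number.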